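The compounds below may be only part of what the source reports. "The series", "measured", "known", "first", "only" and "open" are said of these compounds alone.

Measured so far in an assay for inhibition of Alpha amylase (Homo sapiens), with a stated time of 10 min; a higher number here means a weaker inhibitor, a lower number a stronger inhibitor:
Compound 1, `COc1cccc(-c2nc3cc(F)ccc3[nH]2)c1Cl`, gives 2620 nM.
Compound 2, `COc1ccc(-c2nc3cc(F)ccc3[nH]2)c(Cl)c1OC`, gives 2560 nM.

Among the measured compounds shown here, compound 1 sits alongside compound 2: the only measured step, a 1.0-fold lower number from compound 1 to compound 2 (0.01 log units; within the scatter), is within the scatter, so the two numbers cannot be told apart. Compound 3, `COc1cccc(-c2nc3cc([N+](=O)[O-])ccc3[nH]2)c1Cl`, has not yet been measured. It differs from compound 1 by nitro in place of fluoro on an aromatic carbon. For the measured compounds named here, no measured step touches this part of the shared core, and the one step on record changes a different ring, so it offers no direct guide; it shows only that this read-out stayed put under a small change elsewhere. With nothing pointing in either direction, the expectation for compound 3 is a number close to that of compound 1, with a wider range of doubt: the estimate is 2600 nM, between 900 nM and 7500 nM, which means an expected step of a 1.0-fold lower number from compound 1 to compound 3 (0.00 log units; within the scatter).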

Compound 3, half-maximal inhibitory concentration: 2780 nM
Compound 3: middle estimate off by 1.1-fold (0.03 log units), on the low side; measured number inside the range.
By their numbers in this assay, from the lowest: compounds 2, 1 and 3 (each within the scatter of the next).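

Among the compounds shown here, this is the first change at this position of the shared core, and it is not a small one: nitro has 3 heavy atoms where fluoro has 1, and 2 hydrogen-bond acceptors where fluoro has 0. Even so, in this assay the swap gives a 1.1-fold higher number from compound 1 to compound 3 (0.03 log units; within the scatter) and leaves compound 1 and compound 3 indistinguishable, so for this pair the read-out does not register the exchange. No measurement available here offers an explanation for this result.

The compounds shown leave open whether this position would accept an amine, a carboxylic acid or a longer chain equally well. They also leave open whether nitro would give the same result on compound 2, which carries the extra methoxy group.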